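A few compounds are considered here, and "the series" means these few. Any claim that something is new, unique, unknown or untested is made for them only; others in the source may bear on it.

Three compounds have so far been measured in a functional assay on HT-29 cells (Homo sapiens) for antiproliferative activity, read by sulforhodamine B assay, with a stated time of 48 h; on this read-out lower numbers stand for stronger inhibition and higher numbers for weaker inhibition:

Compound 1 `CN1CCN(c2ccc(S(=O)(=O)Oc3cccc(Br)c3)cc2)C1=O` gives 1300 nM.
Compound 2 `CN1CCN(c2ccc(S(=O)(=O)Oc3cccc(I)c3)cc2)C1=O` gives 590 nM.
Compound 3 `CCN1CCN(c2ccc(S(=O)(=O)Oc3cccc(Br)c3)cc2)C1=O` gives 3800 nM.

Compound 2 differs from compound 1 only by iodo in place of bromo on an aromatic carbon, and this single exchange gave a 2.2-fold lower number from compound 1 to compound 2 (0.34 log units; beyond the scatter). Compound 3 differs from compound 1 by methyl in place of hydrogen on a saturated chain carbon bound to an amide-type nitrogen in a ring, which gave a 2.9-fold higher number from compound 1 to compound 3 (0.47 log units; beyond the scatter), so compound 3 carries the highest number of the three, with compound 2 furthest from it.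

Compound 4 `CCN1CCN(c2ccc(S(=O)(=O)Oc3cccc(I)c3)cc2)C1=O` has not yet been measured. It differs from compound 3 by iodo in place of bromo on an aromatic carbon, the same change, at the same place on the ring, as that which separates compound 2 from compound 1; the two cores differ by methyl in place of hydrogen on a saturated chain carbon bound to an amide-type nitrogen in a ring as told above. In this assay, among the measured compounds shown here, the step from compound 3 to compound 4 is expected to be a 2.2-fold lower number from compound 3 to compound 4 (0.35 log units; beyond the scatter), of a size close to the earlier one, because a 2.2-fold lower number from compound 1 to compound 2 (0.34 log units; beyond the scatter) is the only guide available and it rests on a single pair. Compound 4 is therefore estimated at 1700 nM, with a likely range from 800 nM to 4000 nM.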

Compound 4, half-maximal inhibitory concentration: 3100 nM
Compound 4: middle estimate off by 1.8-fold (0.26 log units), on the low side, and the stated range covers the measured number.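

In this assay iodo in place of bromo on the core of compound 3 gives a 1.2-fold lower number from compound 3 to compound 4 (0.09 log units; within the scatter) and so, taken alone, shows no clear effect, yet this step and the earlier one on the core of compound 1 do not differ by more than the scatter allows: the same change on two cores in this assay, a 2.2-fold lower number (0.34 log units; beyond the scatter) from compound 1 to compound 2 and a 1.2-fold lower number (0.09 log units; within the scatter) from compound 3 to compound 4, 1.8-fold (0.25 log units) apart, within the scatter of two such steps. Methyl in place of hydrogen on the iodo core gives a 5.3-fold higher number from compound 2 to compound 4 (0.72 log units; beyond the scatter) and this step also agrees with its earlier counterpart: the same change on two cores in this assay, a 2.9-fold higher number (0.47 log units; beyond the scatter) from compound 1 to compound 3 and a 5.3-fold higher number (0.72 log units; beyond the scatter) from compound 2 to compound 4, 1.8-fold (0.25 log units) apart, within the scatter of two such steps. Both changes are therefore compatible with carrying over between these two cores, but with a single pair on each core, this does not fix the true size of either step or show that either would hold on any other core.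

Going by these compounds, it remains open whether a chloro or methoxy group in place of the bromo or iodo would follow the same pattern. It is also unknown whether a propyl chain on the amide-type nitrogen in the ring would give a number higher still.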